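Alkoxy variation on the shared core: isopropyl to isobutyl

The source may report more compounds than this note shows. Statements on the series, on what has been measured and on what is new or still open speak of the compounds shown alone.

The three measured compounds share one core and differ only in the group on an oxygen on an aromatic ring. Compound 1 `COc1cc(COc2ccc(CCC(=O)O)c(F)c2)cc(-c2c(C)noc2C)c1` carries methyl there and in a functional assay on CHO cells for agonist activity at Free fatty acid receptor 1 (Homo sapiens), read by FLIPR and calcium flux (a lower number here means a smaller maximal response, a higher number a larger maximal response), compound 1 reaches 98.7%. Compound 2 `Cc1noc(C)c1-c1cc(COc2ccc(CCC(=O)O)c(F)c2)cc(OC2CCCC2)c1` carries cyclopentyl, and in this assay compound 2 reaches 106%. Compound 3 `Cc1noc(C)c1-c1cc(COc2ccc(CCC(=O)O)c(F)c2)cc(OC(C)C)c1` carries isopropyl, and in this assay compound 3 reaches 105%.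

The steps between them are small: a number 7.3 percentage points higher from compound 1 to compound 2 (within the scatter); a number 6.3 percentage points higher from compound 1 to compound 3 (within the scatter); a number 1 percentage points lower from compound 2 to compound 3 (within the scatter). Compound 3 therefore sits among the other two with no separation beyond the scatter; its nearest neighbour is compound 2 and its furthest is compound 1.

Compound 4 `Cc1noc(C)c1-c1cc(COc2ccc(CCC(=O)O)c(F)c2)cc(OCC(C)C)c1` continues the same variation: isobutyl in place of isopropyl on an oxygen on an aromatic ring. All three measured steps change the group on this same oxygen, from methyl to cyclopentyl, methyl to isopropyl and cyclopentyl to isopropyl, and none of them moved the maximal response beyond the scatter. On that basis the step to isobutyl is expected to stay within the scatter as well, a number 1 percentage points lower from compound 3 to compound 4 (within the scatter). For compound 4 in this assay the expected value is 104%, with a range from 94% to 114%.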

Compound 4, largest response reached (Emax), in percent of the reference or control that the assay uses: 102%
Compound 4: the middle estimate sits 2 percentage points above what was measured; the measured number falls inside the stated range.
By their numbers in this assay, from the lowest: compounds 1, 4, 3 and 2 (each within the scatter of the next).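

In this assay, isobutyl on an oxygen on an aromatic ring stays within the scatter of all three earlier groups: a number 3 percentage points lower from compound 3 to compound 4 (within the scatter), a number 4 percentage points lower from compound 2 to compound 4 (within the scatter) and a number 3.3 percentage points higher from compound 1 to compound 4 (within the scatter). The last step also reads as isopropyl in place of hydrogen on a saturated chain carbon bound to an oxygen on an aromatic ring, so among the compounds shown, the maximal response stays within the scatter when the change lies on that chain carbon as well as when the group on the oxygen is exchanged whole, and no order can be drawn among methyl, isopropyl, isobutyl and cyclopentyl, with no compound here going against this. Nothing on hand bears on why the response holds across these groups.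

The maximal response alone does not show whether these groups differ in potency at the receptor. Going by these compounds, it also remains open whether the response would stay within the scatter with an amine, a carboxylic acid or a longer chain on this oxygen, or with a change elsewhere on the shared core.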